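From compound 2 to compound 3: adding phenylsulfonyl

The compounds below may be only part of what the source reports. "The series", "measured", "known", "first", "only" and "open" are said of these compounds alone.

For the measured compounds named here, in an ADME assay on cells (Hepatocyte, Mus musculus) for cytotoxicity, read by MTT assay, with a stated time of 24 h (a higher number here means that more compound is tolerated, a lower number that less compound is tolerated), compound 2 (`FC(F)(F)c1ccc(-c2nn(-c3ccccc3)cc2-c2nc3ccccc3[nH]2)cc1`) gives 159000 nM as the only actual number so far. Compound 1 (`Cc1ccc(-c2nn(-c3ccccc3)cc2-c2nc3ccccc3[nH]2)cc1`) reads > 300000 nM in this assay and that reading is a limit of the assay, not a number.

Compound 3 (`O=S(=O)(c1ccccc1)n1c(-c2cn(-c3ccccc3)nc2-c2ccc(C(F)(F)F)cc2)nc2ccccc21`) carries phenylsulfonyl in place of hydrogen on an aromatic nitrogen and is not yet measured. Going by the values given here, the one measured step, trifluoromethyl in place of methyl on an aromatic carbon, is an at least 1.8-fold lower number from compound 1 to compound 2 (0.27 log units; that floor lies within the scatter) and it changes a carbon substituent rather than this nitrogen, so it offers little guide to size or direction. No step beyond the usual scatter is therefore expected. The estimated change is a 1.3-fold lower number from compound 2 to compound 3 (0.12 log units; within the scatter) and carries wide uncertainty. Compound 3 is expected at 120000 nM (estimated range 40000 nM to 300000 nM) in this assay on this thin evidence.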

Compound 3, half-maximal cytotoxic concentration: 186000 nM
Estimate against measurement, compound 3: 1.6-fold (0.19 log units) below; the range from low to high includes it.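

In this assay, for the compounds shown here, the hydrogen on the aromatic nitrogen of the five-membered aromatic ring can be replaced by phenylsulfonyl, giving a 1.2-fold higher number from compound 2 to compound 3 (0.07 log units; within the scatter) and so no step that can be told apart from repeat measurements. Going by these compounds alone, the earlier step changed only a substituent on an aromatic carbon, so this is the first reading at this nitrogen, and here a whole added aromatic ring with its sulfonyl leaves the two readings level within the scatter. Compound 2 and compound 3 both give actual numbers, so this step has a size, whereas the earlier step had only a floor: the limit of > 300000 nM in this assay, at which 1 of the 3 values shown sits.

Open, from the compounds shown here alone, is whether a methyl, an acetyl or an aminoethyl chain on this nitrogen would read the same way. Also open, going by these compounds, is whether a methoxy or a chlorine on the new phenyl ring would shift the number.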